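The source may hold more compounds than are shown below. What is called first, only, known or untested is meant among the compounds shown, and "the series" means these compounds.

Within the data shown here, in a toxicity assay on L02 cells (Homo sapiens) for cytotoxicity, read by MTT assay, with a stated time of 72 h (on this read-out higher numbers stand for weaker inhibition and lower numbers for stronger inhibition), compound 2 `O=C1c2c[n+]([O-])c3ccccc3c2C(=O)c2[nH]c3ccccc3c21` gives 400 nM, the lowest of the three numbers measured so far. Compound 1 `CN1CCN(CCCCCCn2c3c(c4ccccc42)C(=O)c2c[n+]([O-])c4ccccc4c2C3=O)CC1` gives 3800 nM and compound 3 `CCCCN1CCN(CCCCn2c3c(c4ccccc42)C(=O)c2c[n+]([O-])c4ccccc4c2C3=O)CC1` gives 5690 nM; each carries a substituent on the aromatic nitrogen that compound 2 leaves bare, and each stands at a higher number than compound 2, beyond the scatter. Among the measured compounds shown here, the only measured step, a 1.5-fold higher number from compound 1 to compound 3 (0.18 log units; within the scatter), exchanges one such substituent for another and is within the scatter, so it says nothing about adding a substituent where none was. Compound 4 `O=C1c2c[n+]([O-])c3ccccc3c2C(=O)c2c1c1ccccc1n2CCN1CCCCC1` differs from compound 2 by 2-(piperidin-1-yl)ethyl in place of hydrogen on an aromatic nitrogen, on an aromatic nitrogen of a five-membered aromatic ring with 1 nitrogen, part of a fused or bridged system of five rings. For the measured compounds named here, no measured step covers the move from a bare nitrogen to a substituted one, but the values of compound 1 and compound 3 set against compound 2 point toward a higher number once the nitrogen is substituted. The expected step is therefore a 5.0-fold higher number from compound 2 to compound 4 (0.70 log units; beyond the scatter), toward a higher number. Compound 4 is estimated at 2000 nM, with a range from 600 nM to 6000 nM.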

Compound 4, half-maximal inhibitory concentration: 1050 nM
Beside the measured number, compound 4's estimate is 1.9-fold (0.28 log units) above it; measured number inside the range.
By their numbers in this assay, from the lowest: compound 2; then compound 4; then compounds 1 and 3 (each within the scatter of the next).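

In this assay, among these compounds, a 2.6-fold higher number from compound 2 to compound 4 (0.42 log units; beyond the scatter) gives the first direct reading of a substituent placed on the bare aromatic nitrogen, and 2-(piperidin-1-yl)ethyl moves the number upward, beyond the scatter. Among the compounds shown here, the side chain also proves to matter among the substituted compounds: a 5.4-fold lower number from compound 3 to compound 4 (0.73 log units; beyond the scatter) and a 3.6-fold lower number from compound 1 to compound 4 (0.56 log units; beyond the scatter) both lie beyond the scatter, whereas the only earlier step between substituted compounds stayed within it. No available evidence accounts for these differences.

These steps change the ring and the chain that carries it together, so the compounds shown do not separate the contribution of the piperidine ring from that of the chain. From the compounds shown here alone, how a morpholine ring on the same ethyl chain, or a plain methyl group on this nitrogen, would read in this assay remains open.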